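The source may report more compounds than this note shows. Statements on the series, on what has been measured and on what is new or still open speak of the compounds shown alone.

Compound 1 `CCOC(=O)c1sc(-c2cccc(NC(=O)c3cccc(F)c3)c2)nc1Nc1ccc(N2CCN(C)CC2)cc1` is one of two analogues carrying the same core and differing only in the aryl group on the amide carbonyl. In a functional assay on Raji cells (Homo sapiens) for antiproliferative activity, read by CCK-8 assay, with a stated time of 72 h, tested at 40 uM (a lower number here means less inhibition, a higher number more inhibition at the concentration tested (going by the name of the read-out)), compound 1 gives 82.8%, the higher of the two numbers. Its neighbour, compound 2 `CCOC(=O)c1sc(-c2cccc(NC(=O)c3ccc(C#N)cc3)c2)nc1Nc1ccc(N2CCN(C)CC2)cc1`, gives 79.1% in this assay, and the step of a number 3.7 percentage points lower from compound 1 to compound 2 (within the scatter) lies within the scatter, so the two stand together. Compound 3 `CN1CCN(c2ccc(Nc3nc(-c4cccc(NC(=O)c5cccc(F)c5)c4)sc3C(=O)O)cc2)CC1` is not yet measured; against compound 1 it shows (hydrogen in place of ethyl on an oxygen next to a carbonyl group). For the measured compounds named here, no measured step touches this position, the one step on record concerns the amide aryl and is small, so it gives no guidance on the ester-to-acid change. The expected size of the step of a number 22.8 percentage points lower from compound 1 to compound 3 (beyond the scatter) is therefore uncertain, with a lean toward a lower number. For compound 3 the estimated value in this assay is 60%, within a range from 25% to 88%.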

Compound 3, a percentage reported as inhibition, at one concentration (the size of the read-out at that concentration, not a potency): 76.3%
Compound 3: middle estimate off by 16.3 percentage points, on the low side; the measured number falls inside the stated range.
By their numbers in this assay, from the lowest: compounds 3, 2 and 1 (each within the scatter of the next).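

Hydrogen in place of ethyl on an oxygen next to a carbonyl group is the first change on record at this position, and in this assay it gives a number 6.5 percentage points lower from compound 1 to compound 3 (within the scatter). The earlier step concerned only the aryl group on the amide carbonyl, whereas this one shows that compound 1 and compound 3 stand together at the concentration tested whether the position carries ethoxycarbonyl or carboxy. No evidence at hand accounts for this result.

The compounds shown leave open whether a primary carboxamide, a longer chain such as butoxycarbonyl, or an amine at this position would also stand with them. They also leave open whether the ethoxy to hydroxy change would read the same alongside the 4-cyanophenyl group of compound 2.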